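This account rests on a few compounds, and the source may have more. Where it says the series, first, only, none or still open, it means among the compounds named here.

In a functional assay on PC-12 cells (Rattus norvegicus) for cytotoxicity, read by MTT assay, with stated times of 2 h and 24 h, tested at 1 uM (a lower number here means a weaker effect, a higher number a stronger effect of the compound at the concentration tested), compound 2 `Oc1cc(C(F)(F)F)ccc1-c1nc(-c2ccccc2O)n(-c2ccc(OC(F)(F)F)cc2)n1` gives 65.5%. Among the compounds with values here, its only measured neighbour, compound 1 `CC(C)c1ccc(-n2nc(-c3ccc(C(F)(F)F)cc3O)nc2-c2ccccc2O)cc1`, gives 69.7% in this assay, and the step of a number 4.2 percentage points lower from compound 1 to compound 2 (within the scatter) tells that the two numbers cannot be told apart; compound 2 therefore stands alongside compound 1 rather than apart from it.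

The next compound, compound 3 `Oc1cc(C(F)(F)F)ccc1-c1nc(-c2ccccc2O)n(-c2cccc(F)c2)n1`, differs from compound 2 in one place: 3-fluorophenyl in place of 4-(trifluoromethoxy)phenyl on an aromatic nitrogen. Within the data shown here, the one step measured so far, a number 4.2 percentage points lower from compound 1 to compound 2 (within the scatter), also exchanged one substituent for another and stayed within the scatter. Among the measured compounds shown here, that is the only guide available, and it gives no reason to expect compound 3 to move far from compound 2 in this assay.

For compound 3 the expected step from compound 2 is a number 1.5 percentage points lower from compound 2 to compound 3 (within the scatter), that is, none beyond the scatter. Compound 3 is thus estimated at 64% in this assay, with a likely range from 52% to 76%.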

Compound 3, a percentage reported as activity, at one concentration (the size of the read-out at that concentration, not a potency): 67.2%
For compound 3 the middle estimate is 3.2 percentage points below the measured one, within the range that was stated.
By their numbers in this assay, from the lowest: compounds 2, 3 and 1 (each within the scatter of the next).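

In this assay, putting 3-fluorophenyl on the aromatic nitrogen gives a number 1.7 percentage points higher from compound 2 to compound 3 (within the scatter) and a number 2.5 percentage points lower from compound 1 to compound 3 (within the scatter). Three groups at this position, 4-isopropylphenyl, 4-(trifluoromethoxy)phenyl and 3-fluorophenyl, therefore give numbers that cannot be told apart. This holds although 3-fluorophenyl has fewer heavy atoms than 4-(trifluoromethoxy)phenyl and, as its name shows, carries its substituent at a different ring position from the other two groups. No measurement shown explains why the numbers stay together.

On these data alone, it remains open whether a different kind of group on this nitrogen, such as a phenyl ring bearing an amine or a carboxylic acid, would give a step beyond the scatter. As far as these compounds go, the 2-hydroxyphenyl and 2-hydroxy-4-(trifluoromethyl)phenyl groups are the same in all three compounds, so what changing them would do also remains open.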